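Swapping a Carboxypyridine for a Methylpyridine on the Shared Core

The compounds below may be only part of what the source reports. "The series", "measured", "known", "first", "only" and "open" are said of these compounds alone.

Three compounds share one core. Compound 1 `CCC(C)(C)Cc1c[nH]c(CCc2ccc(N3CCCCC3)cc2)n1` gives 28 nM in an in vitro assay on CHO cells for displacement of a labelled ligand from Bombesin receptor subtype-3 (Homo sapiens), read by scintillation counting, with a stated time of 2 h; a higher number here means a weaker inhibitor, a lower number a stronger inhibitor. Compound 2 `CCC(C)(C)Cc1c[nH]c(CCc2ccc(-n3ccnn3)cc2)n1` gives 390 nM, and compound 3 `CCC(C)(C)Cc1c[nH]c(CCc2ccc(-c3cccnc3C(=O)O)cc2)n1` gives 560 nM, the highest of the three numbers; its nearest neighbour is compound 2, within the scatter, while the step of a 20-fold higher number from compound 1 to compound 3 (1.30 log units; beyond the scatter) is large. Compound 4 `CCC(C)(C)Cc1c[nH]c(CCc2ccc(-c3cccc(C)n3)cc2)n1` differs from compound 3 in one place: 6-methylpyridin-2-yl in place of 2-carboxypyridin-3-yl on an aromatic carbon. Within the data shown here, no measured step matches this change. The steps of a 14-fold higher number from compound 1 to compound 2 (1.14 log units; beyond the scatter) and a 20-fold higher number from compound 1 to compound 3 (1.30 log units; beyond the scatter) show that two different rings in place of piperidin-1-yl both raise the number by similar amounts, and a 1.4-fold higher number from compound 2 to compound 3 (0.16 log units; within the scatter) shows that these two rings barely differ from one another. Another six-membered aromatic ring is therefore expected to give a step of a 1.9-fold lower number from compound 3 to compound 4 (0.27 log units; within the scatter) that stays within the scatter. Compound 4 is estimated at 300 nM, in the range 80 nM to 1100 nM.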

Compound 4, half-maximal inhibitory concentration: 6.3 nM
Compound 4: middle estimate off by 48-fold (1.68 log units), on the high side; measured number outside the range, below it.
By their numbers in this assay, from the lowest: compound 4; then compound 1; then compounds 2 and 3 (each within the scatter of the next).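

This position does not treat all six-membered aromatic rings alike: 6-methylpyridin-2-yl and 2-carboxypyridin-3-yl are each a six-membered aromatic ring with 1 hetero atom, yet the change gives an 89-fold lower number from compound 3 to compound 4 (1.95 log units; beyond the scatter). The new group also beats the other two, with a 62-fold lower number from compound 2 to compound 4 (1.79 log units; beyond the scatter) and, more modestly, a 4.4-fold lower number from compound 1 to compound 4 (0.65 log units; beyond the scatter), so compound 4 has the lowest number of the four. Nothing measured here accounts for this gain. From the compounds shown here alone, whether it comes from the methyl, the place of the ring nitrogen or the loss of the carboxylic acid stays open. A pyridin-2-yl group carrying no methyl, or an ethyl in its place, would help separate these.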